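Adding a Chloro Group to a Growth Inhibitor

This account rests on a few compounds, and the source may have more. Where it says the series, first, only, none or still open, it means among the compounds named here.

Measured compounds:
Compound 1 `O=C(/C(=C/c1ccccc1)CCl)c1ccccc1` gives 12000 nM in a functional assay on HBL-100 cells (Homo sapiens) for inhibition, read by sulforhodamine B assay, with a stated time of 48 h; on this read-out lower numbers stand for stronger inhibition of growth and higher numbers for weaker inhibition of growth.
Compound 2 `O=C(/C(=C/c1ccc(Cl)cc1)CCl)c1ccccc1` gives 3200 nM.
Compound 3 `C=C(C/C(=C\c1ccccc1)C(=O)c1ccccc1)C(=O)c1ccccc1` gives 10000 nM.

Compound 1 and compound 2 differ by one change, (chloro in place of hydrogen on an aromatic carbon), and this gave a 3.8-fold lower number from compound 1 to compound 2 (0.57 log units; beyond the scatter). Compound 3 shares this pattern but has a larger core; how its core differs from that of compound 1 is not broken down here. Compound 4 `C=C(C/C(=C\c1ccc(Cl)cc1)C(=O)c1ccccc1)C(=O)c1ccccc1` is compound 3 with the same change, (chloro in place of hydrogen on an aromatic carbon), made at the same kind of place. Compound 3, at 10000 nM, sits near compound 1. Because the chloro step gave a 3.8-fold lower number from compound 1 to compound 2 (0.57 log units; beyond the scatter), a step of similar size is expected for compound 4, namely a 3.3-fold lower number from compound 3 to compound 4 (0.52 log units; beyond the scatter). Compound 4 is therefore estimated at 3000 nM, expected between 1200 nM and 8000 nM.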

Compound 4, concentration for 50% growth inhibition: 17000 nM
Estimate against measurement, compound 4: 5.7-fold (0.75 log units) below; the measured number lies above the stated range.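

In this assay, the chloro change did not carry over from one core to the other: on the larger core it gave a 1.7-fold higher number from compound 3 to compound 4 (0.23 log units; within the scatter), so the change made no clear difference there. Set side by side, the two steps disagree: the same change on two cores in this assay, a 3.8-fold lower number (0.57 log units; beyond the scatter) from compound 1 to compound 2 and a 1.7-fold higher number (0.23 log units; within the scatter) from compound 3 to compound 4, 6.4-fold (0.80 log units) apart, beyond the scatter of two such steps The drop in number seen on the core of compound 1 therefore cannot be assumed for the core of compound 3, but this single pair on each core neither explains the difference nor sets a rule for the series.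

The compounds shown carry only hydrogen or chloro at this place on the ring. As far as these compounds go, whether a methoxy group, an amine or a carboxylic acid there would behave alike on both cores remains open.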